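This account rests on a few compounds, and the source may have more. Where it says the series, first, only, none or still open, it means among the compounds named here.

Working notes on a series built on one shared core. Compound 1 `NC1=NC2(CCOCC2)N(OCCCOc2cc(Cl)c(Cl)cc2Cl)C(N)=N1`, compound 2 `NC1=NC2(CCSCC2)N(OCCCOc2ccc(Cl)cc2)C(N)=N1` and compound 3 `COc1ccc(OCCCON2C(N)=NC(N)=NC23CCOCC3)cc1` have been tested in a functional assay on A549 cells (Homo sapiens) for antiproliferative activity, read by MTT assay, with a stated time of 72 h; a lower number here means a stronger inhibitor, a higher number a weaker inhibitor. In this assay compound 1 gives 680 nM, compound 2 gives 580 nM and compound 3 gives 660 nM. Compound 2 stands level with the other two: its gaps to compound 3 and to compound 1 are both within the scatter, so no order among the three can be read from these numbers. Among the measured compounds shown here, the only single-point step measured so far, 4-methoxyphenyl in place of 2,4,5-trichlorophenyl on an oxygen on a saturated carbon, gave a 1.0-fold lower number from compound 1 to compound 3 (0.01 log units; within the scatter).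

Compound 4 `NC1=NC2(CCSCC2)N(OCCCOc2cccc(Br)c2)C(N)=N1` is the next compound for this assay. Relative to compound 2 the change is 3-bromophenyl in place of 4-chlorophenyl on an oxygen on a saturated carbon. For the measured compounds named here, this is again an exchange of the aryl group on an oxygen on a saturated carbon, and the one step of that kind already measured, a 1.0-fold lower number from compound 1 to compound 3 (0.01 log units; within the scatter), left the number essentially where it was. A step of no more than the scatter is therefore expected, in no particular direction, and the estimated step is a 1.0-fold higher number from compound 2 to compound 4 (0.01 log units; within the scatter). For compound 4 the expected value in this assay is 600 nM, with a range from 300 nM to 1300 nM.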

Compound 4, half-maximal inhibitory concentration: 50 nM
The estimate for compound 4 lay 12-fold (1.08 log units) above the measured number; measured number outside the range, below it.
By their numbers in this assay, from the lowest: compound 4; then compounds 2, 3 and 1 (each within the scatter of the next).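

In this assay, the aryl group on an oxygen on a saturated carbon proves able to move the number substantially: 3-bromophenyl in place of 4-chlorophenyl gives a 12-fold lower number from compound 2 to compound 4 (1.06 log units; beyond the scatter). Among the compounds shown here, the only earlier exchange at this place, a 1.0-fold lower number from compound 1 to compound 3 (0.01 log units; within the scatter), showed no such movement, so the flat result between those two compounds does not describe this position as a whole. The step is also large for a small change in what is counted: the leaving and entering groups have the same number of heavy atoms and the same aromatic ring, neither has hydrogen-bond donors or acceptors, and neither carries a net charge, leaving the halogen and its place on the ring as the difference.

Both the halogen and its place change in this single step, so the compounds shown cannot separate the two, and no measurement available here accounts for the size of the step. Also open, going by these compounds, are whether the gain carries over to the core of compound 1 and what an amine or a carboxylic acid in place of the bromine would do to the number.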